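The source may hold more compounds than are shown below. What is called first, only, known or untested is meant among the compounds shown, and "the series" means these compounds.

Measured so far in an ADME assay on C8166 cells (Homo sapiens) for cytotoxicity, read by MTT assay, with a stated time of 3 days; a higher number here means that more compound is tolerated, a lower number that less compound is tolerated:
- compound 1 `COCCNC(=O)c1nc(C(C)(C)NC(=O)OCc2ccccc2)nc(O)c1O`: compound 1 gives 348000 nM
- compound 2 `CC(C)(NC(=O)OCc1ccccc1)c1nc(O)c(O)c(NC(=O)NCc2ccc(F)cc2)n1`: compound 2 gives 81100 nM
- compound 3 `COc1ccc(CNC(=O)Nc2nc(C(C)(C)NC(=O)OCc3ccccc3)nc(O)c2O)cc1`: compound 3 gives > 500000 nM

For compound 3 this assay reports only a limit and not a number, and compound 3 sits at the limit of > 500000 nM in this assay, at which 1 of the 3 values shown sits. Compound 4 `COCCNC(=O)Nc1nc(C(C)(C)NC(=O)OCc2ccccc2)nc(O)c1O` differs from compound 3 by methoxymethyl in place of 4-methoxyphenyl on a saturated chain carbon bound to an amide-type nitrogen. Within the data shown here, only one measured step touches this position: an at least 6.1-fold higher number from compound 2 to compound 3 (0.78 log units; beyond the scatter), where the change on the aromatic carbon moved the number toward more compound being tolerated. Compound 4 is expected to stay close to compound 3, with the step of an at least 1.2-fold lower number from compound 3 to compound 4 (0.09 log units; that floor lies within the scatter) estimated to remain within the scatter. The estimate for compound 4 in this assay is 400000 nM, with a range from 150000 nM to 1000000 nM.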

Compound 4, half-maximal cytotoxic concentration: > 500000 nM
Compound 4: only a limit was reported; the forecaster's own chance of this, stated with the estimate: 45%; middle value at least 1.2-fold (0.09 log units) from the limit.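

In this assay, compound 3 and compound 4 each give only a limit, so the step between them cannot be read: the limit of > 500000 nM in this assay, at which 2 of the 4 values shown sit.

Methoxymethyl in place of 4-fluorophenyl gives an at least 6.1-fold higher number from compound 2 to compound 4 (0.78 log units; beyond the scatter), so an aromatic ring on this chain is not required for the number to stand well clear of that of compound 2. The change to ((2-methoxyethyl)carbamoyl)amino in place of (2-methoxyethyl)carbamoyl gives an at least 1.4-fold higher number from compound 1 to compound 4 (0.15 log units; that floor lies within the scatter), which does not settle whether that change matters.

As far as these compounds go, the actual numbers for compound 3 and compound 4 stay unknown. The compounds shown also leave open whether an amine or a carboxylic acid at the end of this chain would bring the number back down from the limit.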